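A bicyclic aryl group replaces 3-methylphenyl

The compounds below may be only part of what the source reports. "The series", "measured", "known", "first", "only" and "open" are said of these compounds alone.

Compound 1 `COc1cc(-c2ccnc3cc(-c4cccc(C#N)c4)nn23)cc(OC)c1OC`: > 10000 nM, a limit of the assay
Compound 2 `COc1cc(-c2ccnc3cc(-c4ccc(N(C)C)cc4)nn23)cc(OC)c1OC`: 2050 nM
Compound 3 `COc1cc(-c2ccnc3cc(-c4cccc(C)c4)nn23)cc(OC)c1OC`: 6150 nM

In a functional assay on HCT-116 cells (Homo sapiens) for inhibition, read by CCK-8 assay, with a stated time of 48 h (a lower number here means a stronger inhibitor, a higher number a weaker inhibitor), compound 3 gives 6150 nM, the higher of the two actual numbers. Compound 4 `COc1cc(-c2ccnc3cc(-c4ccc5ccn(C)c5c4)nn23)cc(OC)c1OC` carries 1-methyl-1H-indol-6-yl in place of 3-methylphenyl on an aromatic carbon of the shared core: 1-methyl-1H-indol-6-yl in place of 3-methylphenyl on an aromatic carbon. For the measured compounds named here, the same aryl position changes in all the measured steps. The clearest are a 3.0-fold higher number from compound 2 to compound 3 (0.48 log units; beyond the scatter) and an at least 4.8-fold lower number from compound 1 to compound 2 (0.68 log units; beyond the scatter), while an at least 1.6-fold lower number from compound 1 to compound 3 (0.21 log units; that floor lies within the scatter) says little. Going by the values given here, no measured compound carries this group, so the direction is uncertain, though compound 2 at 2050 nM shows that a lower number is reachable. The expected change, lower rather than higher, is a 7.7-fold lower number from compound 3 to compound 4 (0.89 log units; beyond the scatter). Compound 4 is estimated at 800 nM, with an expected range of 40 nM to 6000 nM.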

Compound 4, half-maximal inhibitory concentration: 1040 nM
Beside the measured number, compound 4's estimate is 1.3-fold (0.11 log units) below it, within the range that was stated.
By their numbers in this assay, from the lowest: compounds 4 and 2 (each within the scatter of the next); then compound 3. At a limit, above all of these: compound 1.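

Replacing 3-methylphenyl with the bicyclic 1-methyl-1H-indol-6-yl at this aryl position in this assay gives a 5.9-fold lower number from compound 3 to compound 4 (0.77 log units; beyond the scatter), so a fused ring system is tolerated here. Against 4-(dimethylamino)phenyl the change gives a 2.0-fold lower number from compound 2 to compound 4 (0.29 log units; within the scatter), so two quite different aryl groups now stand level, and the dimethylamino group is not required. The value of compound 1 is a limit, and the change from it, an at least 9.6-fold lower number from compound 1 to compound 4 (0.98 log units; beyond the scatter), is only a floor: the limit of > 10000 nM in this assay, at which 1 of the 4 values shown sits.

The compounds shown leave open whether the methyl on the indole nitrogen matters, and what an amine or a carboxylic acid on the bicyclic group would do.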